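Methoxy position on the N-methyl amide aryl

The compounds below may be only part of what the source reports. "The series", "measured", "known", "first", "only" and "open" are said of these compounds alone.

Compound 1 `COc1cccc(C(=O)Nc2cccc3ccc(NS(=O)(=O)c4cc(-c5cccc(C(=O)N(C)C)c5)ccc4OC)cc23)c1`: 473 nM
Compound 2 `COc1ccccc1C(=O)N(C)c1cccc2ccc(NS(=O)(=O)c3cc(-c4cccc(C(=O)N(C)C)c4)ccc3OC)cc12`: > 10000 nM

In a functional assay on CHO cells for agonist activity at Orexin/Hypocretin receptor type 1 (Homo sapiens) (a higher number here means that more compound is needed for the effect, a lower number that less compound is needed), compound 1 gives 473 nM. For compound 2 the assay reports only a limit, not a number; compound 2 sits at the limit of > 10000 nM in this assay, at which 1 of the 2 values shown sits. Among the compounds with values here, the one measured step, an at least 21-fold higher number from compound 1 to compound 2 (1.32 log units; beyond the scatter), changes both the methyl on the amide nitrogen and the methoxy position, so no measured step isolates the change now considered. Compound 3 `COc1ccc(C(=O)N(C)c2cccc3ccc(NS(=O)(=O)c4cc(-c5cccc(C(=O)N(C)C)c5)ccc4OC)cc23)cc1` differs from compound 2 by 4-methoxyphenyl in place of 2-methoxyphenyl on a carbonyl carbon. With nothing to separate the two changes, compound 3 is expected to remain weak, with an at least 1.2-fold lower number from compound 2 to compound 3 (0.09 log units; that floor lies within the scatter) as the expected step. The estimate for compound 3 is 8000 nM, between 2000 nM and 30000 nM.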

Compound 3, half-maximal effective concentration: 654 nM
Compound 3: middle estimate off by 12-fold (1.09 log units), on the high side; measured number below the stated range.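

In this assay, 4-methoxyphenyl in place of 2-methoxyphenyl on the carbonyl carbon gives an at least 15-fold lower number from compound 2 to compound 3 (1.18 log units; beyond the scatter), so on the N-methyl amide the methoxy position alone decides whether activity is seen. Compound 2 is recorded only as a limit: the limit of > 10000 nM in this assay, at which 1 of the 3 values shown sits. The methyl on the amide nitrogen does not by itself abolish activity: the data show a 1.4-fold higher number from compound 1 to compound 3 (0.14 log units; within the scatter), although that step also changes the methoxy position.

As far as these compounds go, how ((3-methoxyphenyl)carbonyl)(methyl)amino compares with these compounds remains open, so the methyl is not yet isolated. Also open, from the compounds shown here alone, is whether an ethyl on the amide nitrogen, or a carboxylic acid in place of the methoxy, is accepted.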